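The source may report more compounds than this note shows. Statements on the series, on what has been measured and on what is new or still open speak of the compounds shown alone.

Measured so far:
compound 1 `O=c1nc2ccccn2cc1Cc1ccc(F)cc1C(F)(F)F`: 8690 nM
compound 2 `O=c1nc2ccccn2cc1Cc1ccc(F)cc1`: 125000 nM

In a functional assay on SK-N-SH cells (Homo sapiens) for cytotoxicity, read by MTT assay, with a stated time of 24 h (on this read-out higher numbers stand for weaker inhibition and lower numbers for stronger inhibition), compound 1 gives 8690 nM, the lower of the two numbers and thus the stronger inhibition of the pair. Going by the values given here, the only measured step is large: a 14-fold higher number from compound 1 to compound 2 (1.16 log units; beyond the scatter), with hydrogen in place of trifluoromethyl on an aromatic carbon. Compound 3 `O=c1nc2ccc(Cl)cn2cc1Cc1ccc(F)cc1C(F)(F)F`, not yet measured, carries chloro in place of hydrogen on an aromatic carbon of the core of compound 1: chloro in place of hydrogen on an aromatic carbon. Among the compounds with values here, no step at this place has been measured. Within the data shown here, the one measured step, a 14-fold higher number from compound 1 to compound 2 (1.16 log units; beyond the scatter), lies at a different place and a different group, so it bears only loosely and its size is not carried over. In this assay a small shift towards a lower number is expected, not clearly beyond the scatter, and its direction is uncertain. The expected step is a 1.4-fold lower number from compound 1 to compound 3 (0.16 log units; within the scatter). For compound 3 the estimated value is 6000 nM, with an expected range of 1500 nM to 25000 nM.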

Compound 3, half-maximal inhibitory concentration: 106000 nM
Beside the measured number, compound 3's estimate is 18-fold (1.25 log units) below it; the measured number lies above the stated range.
By their numbers in this assay, from the lowest: compound 1; then compounds 3 and 2 (each within the scatter of the next).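

In this assay the shared core proves sensitive to substitution: a 12-fold higher number from compound 1 to compound 3 (1.09 log units; beyond the scatter) comes with chloro in place of hydrogen on an aromatic carbon, two atoms from the ring nitrogen. The earlier step, a 14-fold higher number from compound 1 to compound 2 (1.16 log units; beyond the scatter), lay at the trifluoromethyl group, so a large step towards a higher number is now seen at two different places on compound 1. No measured property of these compounds bears on this result, and the step stands without an explanation.

The compounds shown leave open whether the step belongs to chloro itself or to any replacement of hydrogen at this position, which a fluoro, methyl, methoxy or amine group there would help to separate. They also leave open whether chloro at this position has the same effect when the trifluoromethyl group is replaced by hydrogen.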